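The source may hold more compounds than are shown below. What is called first, only, known or untested is meant among the compounds shown, and "the series" means these compounds.

Compound 2 `ClCc1ccc(Cn2cnc3nc(Cl)nc(Cl)c32)cc1` was examined in a functional assay on COLO 205 cells (Homo sapiens) for cytotoxicity, read by sulforhodamine B assay, with a stated time of 48 h; a lower number here means that less compound is tolerated, a higher number that more compound is tolerated. In this assay compound 2 reaches only the limit of > 100000 nM, which is a limit of the measurement and not a number. Compound 1 `ClCc1ccc(Cn2cnc3c(Cl)ncnc32)cc1` likewise gives only the limit of > 100000 nM in this assay. Both values stand at the limit of > 100000 nM in this assay, at which 2 of the 2 values shown sit. Compound 3 `ClCc1ccc(Cn2cnc3ncnc(Cl)c32)cc1` differs from compound 2 by hydrogen in place of chloro on an aromatic carbon. Among the compounds with values here, with no measured step available to guide it, the change is expected to be none beyond the scatter, a number no higher from compound 2 to compound 3 (the limit leaves the size open). Compound 3 is therefore estimated to sit again at a limit, around 100000 nM, with a range from 40000 nM to 300000 nM.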

Compound 3, concentration lethal to 50% of the cells: 7410 nM
For compound 3 the middle estimate is 13-fold (1.13 log units) above the measured one, outside the stated range (below it).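

Replacing chloro with hydrogen on the aromatic carbon between two ring nitrogen atoms gives an at least 13-fold lower number from compound 2 to compound 3 (1.13 log units; beyond the scatter) in this assay. This shows that the group at this position can shift the read-out, which compounds 1 and 2 could not show. Compound 3 is the only one of the three with a number rather than a limit: the limit of > 100000 nM in this assay, at which 2 of the 3 values shown sit.

As far as these compounds go, the full size of the step remains open, as one end of it is a limit. Also open, from the compounds shown here alone, is whether an amine or a methoxy group on this carbon would behave like hydrogen or like chloro.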